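Sulfonyl substitution on the ring nitrogen of compound 1

The compounds below may be only part of what the source reports. "The series", "measured", "known", "first", "only" and "open" are said of these compounds alone.

The shared core is carried by compound 1 `COc1ccc(-c2cc(=O)c3c(OC)cc(OC)cc3[nH]2)cc1`, and the question is what happens in a functional assay on HepG2 cells (Homo sapiens) for antiproliferative activity, with a stated time of 72 h (a higher number here means that more compound is needed for the effect, a lower number that less compound is needed), when its ring nitrogen is substituted. In this assay compound 1 gives > 31100 nM, which is a limit of the assay and not a number. Compound 2 `COc1ccc(-c2cc(=O)c3c(OC)cc(OC)cc3n2Cc2ccccc2)cc1` gives > 17300 nM in this assay, again a limit. Compound 3 `C=CCNC(=O)n1c(-c2ccc(OC)cc2)cc(=O)c2c(OC)cc(OC)cc21` gives > 20000 nM in this assay, also a limit. Going by the values given here, compound 1 therefore stands at one of three limits, and nothing among the measured compounds reaches a readable number.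

Compound 4 `COc1ccc(-c2cc(=O)c3c(OC)cc(OC)cc3n2S(=O)(=O)c2ccc(Br)cc2)cc1` differs from compound 1 in one place: (4-bromophenyl)sulfonyl in place of hydrogen on an aromatic nitrogen. The measured steps that bear on this change are a step that the two limits leave unreadable from compound 1 to compound 2 and a step that the two limits leave unreadable from compound 1 to compound 3, and likewise a step that the two limits leave unreadable from compound 2 to compound 3; none of them can be sized, because each end sits at a limit, as the limit of > 31100 nM in this assay, at which 1 of the 3 values shown sits, the limit of > 17300 nM in this assay, at which 1 of the 3 values shown sits, and the limit of > 20000 nM in this assay, at which 1 of the 3 values shown sits, show. No direction can be read from them, so no step beyond the scatter is expected in this assay, and a further limit is the likeliest outcome.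

Compound 4 is therefore estimated at 30000 nM in this assay, with a range from 8000 nM to 100000 nM, which corresponds to an expected step of an at least 1.0-fold lower number from compound 1 to compound 4 (0.01 log units; that floor lies within the scatter).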

Compound 4, half-maximal effective concentration: 16300 nM
Compound 4: the middle estimate sits 1.8-fold (0.26 log units) above what was measured, within the range that was stated.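

Compound 4 is the only compound shown that gives a readable number in this assay, so substitution on this ring nitrogen is no longer known through limits alone, while the steps among compound 1, compound 2 and compound 3 cannot be read. The readable steps are an at least 1.9-fold lower number from compound 1 to compound 4 (0.28 log units; that floor lies within the scatter), an at least 1.2-fold lower number from compound 3 to compound 4 (0.08 log units; that floor lies within the scatter) and an at least 1.0-fold lower number from compound 2 to compound 4 (0.02 log units; that floor lies within the scatter), so (4-bromophenyl)sulfonyl, whether it replaces hydrogen, allylcarbamoyl or benzyl, shows no change beyond the scatter, and it remains undecided whether this change shifts the number at all. Compound 1 stands at a limit of the assay, and the step from it can therefore be given only as a floor: the limit of > 31100 nM in this assay, at which 1 of the 4 values shown sits.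

The compounds shown leave open whether the bromine of the (4-bromophenyl)sulfonyl group has any part in the readable number, which a phenylsulfonyl group without bromine or a methanesulfonyl group on the same nitrogen would address. They also leave open whether a sulfonyl group carrying an amine or a carboxylic acid on its aromatic ring would give a number clearly separated from the scatter.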